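The source may hold more compounds than are shown below. What is called first, only, known or untested is meant among the compounds shown, and "the series" means these compounds.

Measured compounds:
compound 1 `CC(C)C(=O)OCOC(=O)N1CCN(C(=O)c2nc(Nc3cc(C4CC4)[nH]n3)c3cc(Cl)ccc3n2)C[C@H]1C` with 86.9% in an assay for inhibition of serine/threonine-protein kinase PAK 4 (Homo sapiens), read by FRET and Z'-LYTE, with a stated time of 60 min, tested at 50 uM, in the presence of a further agent that is not named here; on this read-out higher numbers stand for a stronger effect at the one concentration tested and lower numbers for a weaker effect
compound 2 `C[C@@H]1CN(C(=O)c2nc(Nc3cc(C4CC4)[nH]n3)c3cc(Cl)ccc3n2)CCN1C(=O)OCOC(=O)C(C)(C)C` with 60.5% in this assay

For the measured compounds named here, compound 1 stands highest of the two numbers; its nearest neighbour is compound 2, and the single measured step of a number 26.4 percentage points lower from compound 1 to compound 2 (beyond the scatter) alters only the acyl part of the side chain. Compound 3 `CCOC(=O)N1CCN(C(=O)c2nc(Nc3cc(C4CC4)[nH]n3)c3cc(Cl)ccc3n2)C[C@H]1C` differs from compound 1 by methyl in place of (isopropylcarbonyl)oxy on a saturated chain carbon bound to an oxygen next to a carbonyl group. Going by the values given here, no measured step covers this change, since the step from compound 1 to compound 2 changes the (isopropylcarbonyl) group rather than removing it together with the oxygen and carbon that carry it. Among the compounds with values here, the one step that is known was modest and downward, so the expectation for compound 3 in this assay is a step of modest size, more likely downward than upward, with wide uncertainty. Compound 3 is therefore expected to give about 70% (range 40% to 95%). This estimate means a step of a number 16.9 percentage points lower from compound 1 to compound 3 (beyond the scatter).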

Compound 3, a percentage reported as inhibition, at one concentration (the size of the read-out at that concentration, not a potency) in the serine/threonine-protein kinase PAK 4 assay: 93.4%
For compound 3 the middle estimate is 23.4 percentage points below the measured one; low and high end bracket the measured number.
By their numbers in the serine/threonine-protein kinase PAK 4 assay, from the lowest: compound 2; then compounds 1 and 3 (each within the scatter of the next).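

In the serine/threonine-protein kinase PAK 4 assay, compound 1 gives 86.9% and compound 3 gives 93.4%; methyl in place of (isopropylcarbonyl)oxy on a saturated chain carbon bound to an oxygen next to a carbonyl group gives (a number 6.5 percentage points higher from compound 1 to compound 3 (within the scatter)), so at this one concentration the simple ethoxycarbonyl group serves as well as the (((isopropylcarbonyl)oxy)methoxy)carbonyl group. The same replacement of ((tert-butyl)carbonyl)oxy gives (a number 32.9 percentage points higher from compound 2 to compound 3 (beyond the scatter)), which ties the lower number of compound 2 to that group and not to carbamate side chains in general. In a physicochemical assay, read by HPLC, in phosphate buffer, with a stated time of 2 h, at pH 7.4 (on this read-out higher numbers stand for a more stable compound and lower numbers for a less stable compound), compound 1 gives 93.5% and compound 3 gives 97.7%; the replacement gives (a number 4.2 percentage points higher from compound 1 to compound 3 (within the scatter)), and nothing at hand explains any of these numbers.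

Going by these compounds, whether a longer chain such as propyl, or a chain ending in an amine or a carboxylic acid, would behave like ethyl here remains open. The compounds also leave open how these results at a single concentration relate to potency.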